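The source may hold more compounds than are shown below. What is called first, only, known or untested is meant among the compounds shown, and "the series" means these compounds.

Among the measured compounds shown here, in a functional assay on DU-145 cells (Homo sapiens) for inhibition, read by trypan blue exclusion, with a stated time of 96 h (a higher number here means a weaker inhibitor of growth, a lower number a stronger inhibitor of growth), only two compounds have been measured so far. Compound 1 (`O=C(/C(=C\c1ccccc1F)S(=O)(=O)c1ccc(Br)cc1)c1ccc(Cl)cc1`) gives 25000 nM, while compound 2 (`Cc1ccc(S(=O)(=O)/C(=C/c2cc(C)ccc2C)C(=O)c2ccc(Cl)cc2)cc1`) gives 1000 nM, the lower of the two numbers and a gap beyond the scatter. Compound 3 (`Cc1ccc(S(=O)(=O)/C(=C/c2ccccc2F)C(=O)c2ccc(Cl)cc2)cc1`) has not yet been measured. It carries 2-fluorophenyl in place of 2,5-dimethylphenyl on a double-bonded chain carbon bound to a double-bonded chain carbon. For the measured compounds named here, no step between measured compounds shows the effect of this change, so any expectation is tentative. Compound 1 also carries 2-fluorophenyl and gives 25000 nM, which suggests a move towards weaker growth inhibition. The expected change is a 5.0-fold higher number from compound 2 to compound 3 (0.70 log units; beyond the scatter), upward and beyond the scatter. Compound 3 is estimated at 5000 nM, with an expected range from 1500 nM to 20000 nM.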

Compound 3, concentration for 50% growth inhibition: 2500 nM
Compound 3: middle estimate off by 2.0-fold (0.30 log units), on the high side, within the range that was stated.
By their numbers in this assay, from the lowest: compound 2; then compound 3; then compound 1.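

In this assay, 2-fluorophenyl in place of 2,5-dimethylphenyl on a double-bonded chain carbon bound to a double-bonded chain carbon gives a 2.5-fold higher number from compound 2 to compound 3 (0.40 log units; beyond the scatter), so growth inhibition responds to this change, though the step is modest. With 2-fluorophenyl held constant, methyl in place of bromo on an aromatic carbon gives a 10-fold lower number from compound 1 to compound 3 (1.00 log units; beyond the scatter), the larger of the two steps and in the opposite direction on the number scale. Nothing available here accounts for the size of either step.

The compounds shown leave open whether the 2-fluorophenyl step would keep its size with bromo in place of methyl on the aromatic carbon. They also do not show how a methoxy or chloro group on the phenyl ring, or an amine in place of that methyl, would fare.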